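This account rests on a few compounds, and the source may have more. Where it says the series, first, only, none or still open, it means among the compounds named here.

Compound 1 `O=C(/C=C/c1ccccc1)OCC1COCCOCCOCCOCCOCCO1`. In a functional assay on WiDr cells (Homo sapiens) for inhibition, read by sulforhodamine B assay, with a stated time of 48 h (a higher number here means a weaker inhibitor of growth, a lower number a stronger inhibitor of growth), compound 1 gives > 100000 nM, which is a limit of the assay and not a number.
Compound 2 `CC(=O)OCC1COCCOCCOCCOCCOCCO1`. In this assay compound 2 gives > 100000 nM, again a limit of the assay rather than a number.

Compound 2 therefore stands at the limit, and no number places it within the series. For the measured compounds named here, the one measured step, a step that the two limits leave unreadable from compound 1 to compound 2, changes methyl in place of 2-phenylethenyl on a carbonyl carbon, and its size cannot be read since both ends sit at a limit; this is summed up by the limit of > 100000 nM in this assay, at which 2 of the 2 values shown sit.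

Compound 3 `O=C(CCCCc1ccccc1)OCC1COCCOCCOCCOCCOCCO1` differs from compound 2 by 3-phenylpropyl in place of hydrogen on a saturated chain carbon bound to a carbonyl carbon. Going by the values given here, the only measured step bears on it solely in that it joins two compounds at the limit without a readable size, so there is no basis for expecting a step beyond the scatter in either direction in this assay. Compound 3 is estimated to remain at or near the limit, about 150000 nM, within 30000 nM to 1000000 nM. The step this estimate means, a step that the limit leaves unreadable from compound 2 to compound 3, is expected to be nothing beyond the scatter, with the most likely outcome a limit rather than a number.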

Compound 3, concentration for 50% growth inhibition: > 100000 nM
Compound 3 gave a limit, no number; the forecaster's own chance of this, stated with the estimate: 75%; the middle value is on the limit's open side.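

No new step can be read: the steps joining compound 3 to compound 2 and to compound 1 cannot be read, since both ends of each sit at a limit. The compounds shown leave open whether any group on the carbonyl carbon of the shared core gives a readable number in this assay: the limit of > 100000 nM in this assay, at which 3 of the 3 values shown sit.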